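This account rests on a few compounds, and the source may have more. Where it says the series, first, only, none or still open, it means among the compounds named here.

Measured in an ADME assay on MDBK cells (Bos taurus) for cytotoxicity, read by MTT assay, with a stated time of 96 h; on this read-out higher numbers stand for lower toxicity in this test and lower numbers for higher toxicity in this test:
Compound 1 `COc1ccc(-c2nc3cc(/C(C)=N/NC(N)=O)ccc3n2C2CCCCC2)cc1`: 54000 nM
Compound 2 `C/C(=N\NC(N)=S)c1ccc2c(c1)nc(-c1ccc(Cl)cc1)n2C1CCCCC1`: > 100000 nM, a limit
Compound 3 `C/C(=N\NC(N)=S)c1ccc2c(c1)nc(-c1ccc(C(F)(F)F)cc1)n2C1CCCCC1`: > 100000 nM, a limit

Compound 3 has no exact number in this assay, since its > 100000 nM is a limit. Compound 2 stands in the same position, so the set shows (the limit of > 100000 nM in this assay, at which 2 of the 3 values shown sit).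

The next compound is compound 4 `COc1ccc(-c2nc3cc(/C(C)=N/NC(N)=S)ccc3n2C2CCCCC2)cc1`. It differs from compound 3 by methoxy in place of trifluoromethyl on an aromatic carbon, para to a large group.

Going by the values given here, the one measured step of this kind is a step that the two limits leave unreadable from compound 2 to compound 3, so it offers no size to carry over. The nearest guide is compound 1, which also carries 4-methoxyphenyl and gives 54000 nM, a measured number rather than a limit. It differs from compound 4 elsewhere, however, so it serves only as a loose pointer.

On that basis, a modest move toward lower numbers is expected, meaning somewhat higher toxicity in this assay, although compound 4 may well remain at the limit. The expected change is an at least 1.1-fold lower number from compound 3 to compound 4 (0.07 log units; that floor lies within the scatter). The estimated value for compound 4 is 85000 nM, with an expected range of 35000 nM to 100000 nM.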

Compound 4, half-maximal cytotoxic concentration: 32000 nM
For compound 4 the middle estimate is 2.7-fold (0.42 log units) above the measured one; the whole stated range lies above it.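

In this assay, going by these compounds alone, the change at this aromatic carbon, para to a large group, gives an at least 3.1-fold lower number from compound 3 to compound 4 (0.49 log units; beyond the scatter), and methoxy in place of chloro at the same place gives an at least 3.1-fold lower number from compound 2 to compound 4 (0.49 log units; beyond the scatter), so compound 4 is the first sulfur-bearing compound here with a readable number. Both steps are only minimum sizes, because each starts from a compound that sits at a limit: the limit of > 100000 nM in this assay, at which 2 of the 4 values shown sit.

Compound 4 also allows a comparison with compound 1, the other 4-methoxyphenyl compound, and the exchange of the oxygen-bearing group on the amine nitrogen for the sulfur-bearing one gives a 1.7-fold lower number from compound 1 to compound 4 (0.23 log units; within the scatter), so in this assay the two cannot be told apart and the readable numbers in this set belong to the two compounds with 4-methoxyphenyl.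

As far as these compounds go, the step between compound 2 and compound 3 cannot be read, so any difference between chloro and trifluoromethyl stays unknown. Also open, from the compounds shown here alone, is whether an amine or a hydroxyl at the same aromatic carbon would bring a readable number as methoxy does, and how the oxygen-bearing group on the amine nitrogen would read alongside chloro or trifluoromethyl.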